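The source may report more compounds than this note shows. Statements on the series, on what has been measured and on what is new or still open speak of the compounds shown alone.

Measured compounds:
- Compound 1 `Clc1cccc(-c2cnnn2Cc2ccccc2)c1Cl`: in a functional assay for antagonist activity at P2X purinoceptor 7 (Homo sapiens) (a higher number here means a weaker inhibitor, a lower number a stronger inhibitor), compound 1 gives 603 nM.
- Compound 2 `COc1ccccc1Cn1cnnc1-c1cccc(Cl)c1Cl`: in this assay compound 2 gives 191 nM.

Of the two values in hand, compound 2 has the lower one. Its nearest neighbour on the numbers is compound 1, whose value stands higher by a margin that lies beyond the scatter of the measurement. Going by the values given here, the two compounds share the dichlorophenyl-bearing core and differ in more than one place, so no single step between them is counted here; their two values simply show compound 2 at the stronger end.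

Compound 3 `FC(F)(F)c1ccccc1Cn1cnnc1-c1cccc(Cl)c1Cl` is not yet measured. It derives from compound 2 by one change, (trifluoromethyl in place of methoxy on an aromatic carbon). Among the compounds with values here, no measured pair shows this change, so its effect cannot be read from the data in hand. The expectation is therefore cautious: a step from compound 2 to compound 3 of a 1.3-fold higher number from compound 2 to compound 3 (0.12 log units; within the scatter), that is, no move beyond the scatter in either direction. In this assay compound 3 is expected to give 250 nM, within a range from 80 nM to 800 nM.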

Compound 3, half-maximal inhibitory concentration: 132 nM
For compound 3 the middle estimate is 1.9-fold (0.28 log units) above the measured one, and the stated range covers the measured number.
By their numbers in this assay, from the lowest: compounds 3 and 2 (each within the scatter of the next); then compound 1.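

With compound 2 and compound 3, the compounds shown first offer a pair that differs in one place, and in this assay trifluoromethyl in place of methoxy on an aromatic carbon, ortho to a large group, gives a 1.4-fold lower number from compound 2 to compound 3 (0.16 log units; within the scatter). The two groups therefore cannot be told apart by this read-out at this position, even though methoxy carries a hydrogen-bond acceptor and trifluoromethyl carries none, and the entering group has more heavy atoms than the one that leaves. No measurement of any property of these two groups is available to explain this result.

The compounds shown leave open whether an amine, a carboxylic acid or a longer chain on the same aromatic carbon would also give a number within the scatter of those of compound 2 and compound 3, and whether trifluoromethyl or methoxy on another carbon of that ring would do so. Compound 1 differs from compound 2 and compound 3 in more than one place, so the part played by its core and by the methoxy or trifluoromethyl group cannot be separated.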